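From Methyl to Hydroxy: An Expected Gain in Potency

The source may hold more compounds than are shown below. What is called first, only, known or untested is meant among the compounds shown, and "the series" means these compounds.

Compound 1, `COc1ccc2c(=O)c(Cc3coc4cccc(OCC5CCCCC5)c4c3=O)coc2c1`, gives 1320 nM in a functional assay on NCI-H23 cells (Homo sapiens) for antiproliferative activity, read by XTT assay; on this read-out lower numbers stand for stronger inhibition and higher numbers for weaker inhibition.
Compound 2, `Cc1ccc2c(=O)c(Cc3coc4cccc(OCC5CCCCC5)c4c3=O)coc2c1`, gives 3220 nM in this assay.

Compound 2 holds the highest of the two numbers; the only other, compound 1, sits below it by the step of a 2.4-fold higher number from compound 1 to compound 2 (0.39 log units; beyond the scatter). Compound 3, `O=c1c(Cc2coc3cccc(OCC4CCCCC4)c3c2=O)coc2cc(O)ccc12`, differs from compound 2 by hydroxy in place of methyl on an aromatic carbon. Among the compounds with values here, the one measured step that bears on this change is a 2.4-fold higher number from compound 1 to compound 2 (0.39 log units; beyond the scatter), where methyl replaced an oxygen-bearing methoxy and the number rose. Since hydroxy also carries oxygen, compound 3 is expected to move back toward the lower number, by about a 2.1-fold lower number from compound 2 to compound 3 (0.33 log units; beyond the scatter). Compound 3 is therefore estimated at 1500 nM, with a range from 600 nM to 4000 nM.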

Compound 3, half-maximal inhibitory concentration: 2150 nM
Compound 3: the middle estimate sits 1.4-fold (0.16 log units) below what was measured; measured number inside the range.
By their numbers in this assay, from the lowest: compounds 1, 3 and 2 (each within the scatter of the next, the first and the last beyond it).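

Replacing methyl with hydroxy on this aromatic carbon gives a 1.5-fold lower number from compound 2 to compound 3 (0.18 log units; within the scatter) in this assay, so this change cannot be told apart from no change at all. Removing the methyl from the methoxy oxygen gives a 1.6-fold higher number from compound 1 to compound 3 (0.21 log units; within the scatter), so compound 3 also cannot be separated from compound 1, and hydroxy sits within the scatter of both other groups at this position. No available evidence explains these results.

On these data alone, whether an amine, a carboxylic acid or a longer chain such as ethoxy here would stand clearly apart from these three remains open.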